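The source may report more compounds than this note shows. Statements on the series, on what has been measured and on what is new or still open speak of the compounds shown alone.

Of the compounds shown here, two have been measured in a functional assay on CCRF-CEM cells (Homo sapiens) for inhibition, read by sulforhodamine B assay, with a stated time of 48 h, tested at 10 uM; on this read-out higher numbers stand for more inhibition at the one concentration tested (going by the name of the read-out) and lower numbers for less inhibition. Compound 1 `Clc1ccc(-c2cn3ccnc3c(-c3ccc4ncn(C5CCCCC5)c4c3)n2)cc1` gives 11.4% in this assay. Compound 2 `CCc1ccc(-c2cn3ccnc3c(-c3ccc4ncn(Cc5ccccc5)c4c3)n2)cc1` gives 49.7% in this assay, the higher of the two numbers; its nearest neighbour is compound 1, whose number lies lower by more than the usual scatter. Compound 3 `Cc1cccc(-c2cn3ccnc3c(-c3ccc4ncn(Cc5ccccc5)c4c3)n2)c1` has not yet been measured. It differs from compound 2 in one place: 3-methylphenyl in place of 4-ethylphenyl on an aromatic carbon. Among the measured compounds shown here, with no measured step of this kind to lean on, the change from compound 2 to compound 3 is expected to be small, perhaps a slight loss, perhaps none beyond the scatter, so that a number 9.7 percentage points lower from compound 2 to compound 3 (within the scatter) is the estimated step. Compound 3 is therefore expected to give about 40% in this assay, most likely between 20% and 60%.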

Compound 3, a percentage reported as inhibition, at one concentration (the size of the read-out at that concentration, not a potency): 21.1%
Compound 3: middle estimate off by 18.9 percentage points, on the high side; measured number inside the range.
By their numbers in this assay, from the lowest: compounds 1 and 3 (each within the scatter of the next); then compound 2.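

In this assay, putting 3-methylphenyl in place of 4-ethylphenyl on this aromatic carbon gives a number 28.6 percentage points lower from compound 2 to compound 3 (beyond the scatter). Among the compounds shown here, this is the first comparison that changes one place only, and it shows that the read-out responds to the group at this position, even though both groups are a phenyl ring with a small carbon chain. No measurement at hand says why the number falls.

The step changes both the chain and its place on the phenyl ring, so the two effects remain tangled. On these data alone, a 4-methylphenyl or 3-ethylphenyl group would separate them, and how an amine on that ring would read remains open.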